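Thiophen-3-yl for furan-3-yl on a shared core

The source may hold more compounds than are shown below. What is called first, only, known or untested is meant among the compounds shown, and "the series" means these compounds.

Compound 1 (`CSc1ncnc2c1c(-c1ccoc1)cn2[C@@H]1O[C@H](CO)[C@@H](O)[C@H]1O`): > 15000 nM (a limit)
Compound 2 (`Nc1nc(N)c2c(-c3ccsc3)cn([C@@H]3O[C@H](CO)[C@@H](O)[C@H]3O)c2n1`): > 20000 nM (a limit)
Compound 3 (`COc1nc(N)nc2c1c(-c1ccoc1)cn2[C@@H]1O[C@H](CO)[C@@H](O)[C@H]1O`): > 20000 nM (a limit)

All three were tested in a functional assay on HepG2 cells (Homo sapiens) for antiproliferative activity, read by XTT assay, with a stated time of 72 h (on this read-out lower numbers stand for stronger inhibition and higher numbers for weaker inhibition), and none gave a number. Compound 3 stands at the limit of > 20000 nM in this assay, at which 2 of the 3 values shown sit, and so offers only a limit. Compound 4 (`COc1nc(N)nc2c1c(-c1ccsc1)cn2[C@@H]1O[C@H](CO)[C@@H](O)[C@H]1O`) carries thiophen-3-yl in place of furan-3-yl on an aromatic carbon. Compound 2 also bears thiophen-3-yl and likewise reaches only a limit at > 20000 nM in this read-out. For the measured compounds named here, no measured pair shows this exchange alone. The estimated step is a number no higher from compound 3 to compound 4 (the limit leaves the size open) and no shift beyond the scatter is expected in either direction. In this assay compound 4 is estimated at 20000 nM (expected range 7000 nM to 40000 nM), quite possibly reported as a limit again.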

Compound 4, half-maximal inhibitory concentration: > 20000 nM
Compound 4: no number, only a limit; the forecaster's own chance of this, stated with the estimate: 80%; the middle value sits exactly at the limit.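

Compound 4, like compound 2 and compound 3, gives only a limit in this assay, and the steps from compound 2 and compound 3 to compound 4 cannot be read. The compounds shown leave open how thiophen-3-yl compares with furan-3-yl, and methoxy with amino.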